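The source may report more compounds than this note shows. Statements on the series, on what has been measured and on what is new or still open speak of the compounds shown alone.

The measured compounds:

In a functional assay on MCF7 cells (Homo sapiens) for cytotoxicity, read by MTT assay, with a stated time of 72 h (a higher number here means a weaker inhibitor, a lower number a stronger inhibitor), compound 1, `O=C(Nc1ccc(Oc2ccnc3[nH]ccc23)c(F)c1)c1ccc(-c2ccccc2)cn1`, gives 4390 nM.
In this assay compound 2, `Cc1ccc(-c2ccc(C(=O)Nc3ccc(Oc4ccnc5[nH]ccc45)c(F)c3)nc2)cc1`, gives 8020 nM.
In this assay compound 3, `O=C(Nc1ccc(Oc2ccnc3[nH]ccc23)c(F)c1)c1cc(-c2ccccc2)ccn1`, gives > 10000 nM, which is a limit of the assay and not a number.

Compounds 1 and 2 share a core and differ only in one change, (methyl in place of hydrogen on an aromatic carbon). That change produced a 1.8-fold higher number from compound 1 to compound 2 (0.26 log units; within the scatter). Compound 3 is built from the same atoms as compound 1 joined differently; how the two cores differ is not broken down here. The reading for compound 3 sits at the limit of > 10000 nM in this assay, at which 1 of the 3 values shown sits, so only a limit is known for it.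

Compound 4, `Cc1cccc(-c2ccnc(C(=O)Nc3ccc(Oc4ccnc5[nH]ccc45)c(F)c3)c2)c1`, has not yet been measured. It differs from compound 3 by methyl in place of hydrogen on an aromatic carbon. For the measured compounds named here, this is the same kind of change as the one from compound 1 to compound 2, though not the same: in compound 2 the methyl sits para to a large group, whereas in compound 4 it sits meta to a large group. In this assay the expected step from compound 3 to compound 4 is a step that the limit leaves unreadable from compound 3 to compound 4, a step of about the same size as the earlier one, because the earlier methyl addition gave a 1.8-fold higher number from compound 1 to compound 2 (0.26 log units; within the scatter) and stayed within the scatter. Since the starting point for compound 3 is itself a limit, compound 4 is expected to come in at 15000 nM, somewhere between 7000 nM and 40000 nM, and most likely to be reported only as a limit again.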

Compound 4, half-maximal inhibitory concentration: 9120 nM
Beside the measured number, compound 4's estimate is 1.6-fold (0.22 log units) above it, and the stated range covers the measured number.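

In this assay, the change from phenyl to 3-methylphenyl, a methyl in place of hydrogen on an aromatic carbon of a six-membered aromatic ring of carbon only, gave an at least 1.0-fold lower number from compound 3 to compound 4 (0.04 log units; that floor lies within the scatter). For compound 3, the reading of > 10000 nM is a limit of the assay and not a number. On the core of compound 1 the methyl step lies within the scatter, while on the core of compound 3 only its floor is known, so no difference between the two cores is established, and neither is it shown that the change carries over with the same size or direction: the same change on two cores in this assay, a 1.8-fold higher number (0.26 log units; within the scatter) from compound 1 to compound 2 and an at least 1.0-fold lower number (0.04 log units; that floor lies within the scatter) from compound 3 to compound 4; the limit leaves it open whether they differ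

The compounds shown leave open how the series responds on the phenyl ring to a group other than methyl, such as an amine, a carboxylic acid or a longer chain. They also leave open what number compound 3 would give in place of its limit, and with it the true size of the step on that core.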